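A Methoxycarbonyl Takes the Place of Fluoro

This account rests on a few compounds, and the source may have more. Where it says the series, first, only, none or still open, it means among the compounds named here.

In a functional assay on the whole organism for positive allosteric modulation, with Mus musculus as the target (a lower number here means that less compound is needed, a higher number that more compound is needed for the effect), compound 1 `CCC(=O)N(c1ccc(OC)cc1)C1CCCC1N(C)C` gives > 50 mg/kg; > 50 mg/kg (2 entries) as a limit of the measurement and not a number. Compound 2 `CCC(=O)N(c1ccc(F)cc1)C1CCCC1N(C)C` likewise stands only at a limit, with > 50 mg/kg as its sole result. The change methoxycarbonyl in place of fluoro on an aromatic carbon puts methoxycarbonyl in place of fluoro on an aromatic carbon in compound 3 `CCC(=O)N(c1ccc(C(=O)OC)cc1)C1CCCC1N(C)C` and leaves the shared core untouched. Among the compounds with values here, no measured step is available, so the estimated change a step that the limit leaves unreadable from compound 2 to compound 3 in this assay is expected to stay within the scatter, with no clear direction. Compound 3 is expected near 60 mg/kg with an estimated range from 25 mg/kg to 120 mg/kg and may well come out only as a limit.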

Compound 3, dose for half-maximal effect: > 50 mg/kg
Compound 3 ended at the assay's limit; the forecaster's own chance of this, stated with the estimate: 75%; the middle value does not contradict the limit.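

In this assay compound 3 gives > 50 mg/kg, a limit of the measurement and not a number. Compound 2 also stands at a limit, so no step can be read between compound 2 and compound 3. The compounds shown leave open whether methoxycarbonyl in place of fluoro alters the dose needed at all: the limit of > 50 mg/kg in this assay, at which 2 of the 3 values shown sit.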